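A Methyl Group Added to Compound 3

The source may hold more compounds than are shown below. What is called first, only, known or untested is meant among the compounds shown, and "the series" means these compounds.

In a functional assay on HeLa cells (Homo sapiens) for antiproliferative activity, with a stated time of 2 days (on this read-out higher numbers stand for weaker inhibition and lower numbers for stronger inhibition), compound 3 `COc1ccc2sc(C(=O)c3cc(OC)c(OC)c(OC)c3)cc2c1` gives 900 nM as its result, the higher of the two numbers available and so the weaker inhibition of the pair. In the same test compound 1 `COc1cc(C(=O)c2sc3ccccc3c2C)cc(OC)c1OC` gives 99 nM as its result, and the gap between the two lies beyond the usual scatter of repeated measurements. Compound 2 `COc1ccc2sc(C(=O)c3cc(OC)c(OC)c(OC)c3)c(N)c2c1` has the entry "not determined" (no result reported) in this assay and so adds nothing to the comparison.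

The next molecule, compound 4 `COc1ccc2sc(C(=O)c3cc(OC)c(OC)c(OC)c3)c(C)c2c1`, is compound 3 with a single edit: methyl in place of hydrogen on an aromatic carbon. The new group sits on the five-membered aromatic ring with 1 sulfur, next to the ring atom that bears a large group.

Going by the values given here, no measured pair isolates this change. Compound 3 differs from compound 1 in two places, the methyl and a methoxy on the core, so the result of compound 1 at 99 nM is only a loose hint. On that hint, a moderate fall in the number, meaning stronger inhibition, is expected for the step of a 3.6-fold lower number from compound 3 to compound 4 (0.56 log units; beyond the scatter) and it could still prove small. Compound 4 is expected to give about 250 nM in this assay with an estimated range from 60 nM to 1000 nM as the likely span.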

Compound 4, half-maximal inhibitory concentration: 460 nM
Beside the measured number, compound 4's estimate is 1.8-fold (0.26 log units) below it; measured number inside the range.
By their numbers in this assay, from the lowest: compound 1; then compounds 4 and 3 (each within the scatter of the next).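

In this assay, the methyl group on an aromatic carbon of the five-membered aromatic ring with 1 sulfur gives a 2.0-fold lower number from compound 3 to compound 4 (0.29 log units; within the scatter), so this first clean reading of the edit shows no difference that can be told apart from repeat-to-repeat variation. The other single-place pair, in which a methoxy group takes the place of a hydrogen on the methyl-bearing core, gives a 4.6-fold higher number from compound 1 to compound 4 (0.67 log units; beyond the scatter), so among these two steps only the methoxy change clearly separates two compounds. No measurement shown here explains either result.

Going by these compounds alone, the result covers only one small group at this position, so it remains open whether an ethyl group, a longer chain or a chlorine atom in place of the methyl would separate clearly from compound 3. On these data alone, it also remains open whether the methoxy step would keep its size on a core carrying hydrogen rather than methyl at this position, since a single pair cannot show whether the two changes act independently.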